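Two benzisoxazole acids and a third awaiting measurement

The source may hold more compounds than are shown below. What is called first, only, known or untested is meant among the compounds shown, and "the series" means these compounds.

The study rests on two measured compounds and one that is not yet measured. Compound 1 `O=C(O)/C=C/c1ccc2noc(-c3ccc(OC(F)(F)F)cc3)c2c1` carries an acrylic acid on the shared core, and in an assay for inhibition of inositol hexakisphosphate kinase 3 (Homo sapiens), read by colorimetric assay, coupled enzyme assay and malachite green, with a stated time of 120 min, in the presence of a further agent that is not named here (a lower number here means a stronger inhibitor, a higher number a weaker inhibitor), compound 1 gives 8370 nM. Compound 2 `O=C(O)c1ccc2noc(-c3ccc(-c4ccncc4)cc3)c2c1` carries the acid directly on the core, and in this assay compound 2 gives 670 nM. Of these two numbers, compound 2 holds the lower one, and the gap to compound 1 is beyond the usual scatter, so compound 2 is the stronger inhibitor of the pair.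

Compound 3 `O=C(O)c1ccc2noc(-c3ccc(NC(=O)C4CCCC4)cc3)c2c1` keeps the acid of compound 2 and changes only the group on the phenyl ring: (cyclopentylcarbonyl)amino in place of pyridin-4-yl on an aromatic carbon. For the measured compounds named here, no measured pair differs in one place, so there is no observed step to lean on for this change. The author expects the step from compound 2 to compound 3 to be modest, in the direction of a weaker inhibitor, estimated at a 2.2-fold higher number from compound 2 to compound 3 (0.35 log units; beyond the scatter), though within a range that also admits no change beyond the scatter. For compound 3 in this assay the estimate is 1500 nM, expected to fall between 400 nM and 6000 nM.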

Compound 3, half-maximal inhibitory concentration: 240 nM
Estimate against measurement, compound 3: 6.3-fold (0.80 log units) above; measured number outside the range, below it.
By their numbers in this assay, from the lowest: compound 3; then compound 2; then compound 1.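

For the compounds shown here, this is the first step that changes one place alone, on an aromatic carbon of a six-membered aromatic ring of carbon only, para to a large group. In this assay, putting (cyclopentylcarbonyl)amino in place of pyridin-4-yl gives a 2.8-fold lower number from compound 2 to compound 3 (0.45 log units; beyond the scatter), which shows that, for this pair, a pyridin-4-yl group is not needed at this position and that a group with a five-membered non-aromatic ring of carbon only, joined through an amide, gives the stronger inhibitor. The data offer no explanation for the lower number, and this single step does not separate the contribution of the amide link from that of the ring it carries.

Still open, as far as these compounds go, is how the number would respond to an N-methyl amide, which lacks the amide hydrogen, or to a cyclohexyl ring or a short open chain such as methyl in place of the cyclopentyl ring. Also open, from the compounds shown here alone, is what a tetrazole in place of the carboxylic acid would do, and how the acrylic acid of compound 1 would behave alongside either group on the ring.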